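The source may report more compounds than this note shows. Statements on the series, on what has been measured and on what is new or still open speak of the compounds shown alone.

In a functional assay on MCF cells (Homo sapiens) for antiproliferative activity, with a stated time of 72 h (on this read-out lower numbers stand for stronger inhibition and higher numbers for weaker inhibition), compound 1 `OC[C@H]1O[C@@H](n2cnc3c(NCc4cc(F)cc(F)c4)ncnc32)C(O)C1O` gives only a limit, > 166000 nM, and no number. Compound 2 `OC[C@H]1O[C@@H](n2cnc3c(NCc4ccc(F)c(Cl)c4)ncnc32)[C@H](O)[C@@H]1O` also gives only a limit, > 166000 nM. Compound 3 `Cc1ccc(O)c(CNc2ncnc3c2ncn3[C@@H]2O[C@H](CO)[C@@H](O)[C@H]2O)c1` likewise gives only a limit, > 166000 nM. The measurements so far therefore amount to the limit of > 166000 nM in this assay, at which 3 of the 3 values shown sit. Compound 4 `OC[C@H]1O[C@@H](n2cnc3c(NCc4ccccc4C(F)(F)F)ncnc32)C(O)C1O` alters compound 1 in one place: 2-(trifluoromethyl)phenyl in place of 3,5-difluorophenyl on a saturated chain carbon bound to a nitrogen on an aromatic ring. Within the data shown here, the one measured step that bears on this change is a step that the two limits leave unreadable from compound 2 to compound 3, which replaces a phenyl group at the same place, but it has no readable size. Among the measured compounds shown here, no step of known size can be carried over, so no clear step in either direction is expected in this assay. The expected step is a number no higher from compound 1 to compound 4 (the limit leaves the size open). For compound 4, the estimate is 166000 nM, with an expected range of 60000 nM to 400000 nM.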

Compound 4, half-maximal inhibitory concentration: > 166000 nM
Compound 4: only a limit was reported (the forecaster's own chance of this, stated with the estimate: 85%); the middle value lies on the limit itself.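

Among these compounds, compound 1 and compound 4 each give only a limit in this assay and so no step between them can be read. The compounds shown leave open whether any group at this place gives a measurable value, as all share one result: the limit of > 166000 nM in this assay, at which 4 of the 4 values shown sit.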